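The compounds below may be only part of what the source reports. "The series", "measured", "known", "first", "only" and "open" are said of these compounds alone.

Notes on the series. Compound 1 `COC(=O)c1ccc(COC(COCc2ccc(OC)cc2)Cn2ccnc2)cc1` gives 1260 nM in a functional assay for inhibition of Thromboxane-A synthase (Homo sapiens); on this read-out lower numbers stand for stronger inhibition and higher numbers for weaker inhibition; compound 2 `COc1ccc(COCC(Cn2ccnc2)OCc2ccc(C(=O)Oc3ccccc3)cc2)cc1` gives 560 nM; compound 3 `COc1ccc(COCC(Cn2ccnc2)OCc2ccc3c(c2)COC3=O)cc1` gives 6200 nM, the highest of the three numbers. Two steps are known: a 2.3-fold lower number from compound 1 to compound 2 (0.35 log units; beyond the scatter) and a 4.9-fold higher number from compound 1 to compound 3 (0.69 log units; beyond the scatter). Compound 4 `COc1ccc(COCC(Cn2ccnc2)OCc2ccc(S(C)(=O)=O)cc2)cc1` carries a group of 10 heavy atoms (7 carbon, 2 oxygen, 1 sulfur; one six-membered aromatic ring of carbon only) in place of a group of 10 heavy atoms (8 carbon, 2 oxygen; one five-membered non-aromatic ring with 1 hetero atom, one six-membered aromatic ring of carbon only), on a saturated chain carbon bound to an oxygen on a saturated carbon. Among the measured compounds shown here, no step from compound 3 itself covers this change; the nearest guide is that compound 1 sits well below compound 3 because a 4.9-fold higher number from compound 1 to compound 3 (0.69 log units; beyond the scatter) shows the number rising when the fused five-membered ring enters, and compound 4 returns to a single six-membered aromatic ring as in compound 1 and compound 2. For compound 4 the expected step is a 4.1-fold lower number from compound 3 to compound 4 (0.62 log units; beyond the scatter). Compound 4 is estimated at 1500 nM, range 500 nM to 4500 nM.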

Compound 4, half-maximal inhibitory concentration: 24900 nM
Compound 4: middle estimate off by 17-fold (1.22 log units), on the low side; measured number above the stated range.
By their numbers in this assay, from the lowest: compound 2; then compound 1; then compound 3; then compound 4.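

In this assay a single six-membered aromatic ring on this saturated chain carbon's oxygen-linked group does not by itself keep the number low: methylsulfonyl in place of methoxycarbonyl gives a 20-fold higher number from compound 1 to compound 4 (1.30 log units; beyond the scatter) and methylsulfonyl in place of phenoxycarbonyl gives a 44-fold higher number from compound 2 to compound 4 (1.65 log units; beyond the scatter). The group leaving compound 3 also stands below 4-(methylsulfonyl)phenyl, with a 4.0-fold higher number from compound 3 to compound 4 (0.60 log units; beyond the scatter), so all three carbonyl-bearing groups give lower numbers than the sulfonyl group.

No measurement here accounts for this rise. As far as these compounds go, whether a carboxylic acid or a primary amide on that aromatic carbon would stay near the esters remains open.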